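A Methyl Takes the Place of Bromine on the Pendant Ring

The compounds below may be only part of what the source reports. "The series", "measured", "known", "first", "only" and "open" are said of these compounds alone.

Among the compounds with values here, compound 3 `Cc1ccc(-c2c(S(=O)(=O)c3ccccc3)cnc3cc(-c4ccc(Br)cc4)nn23)cc1` gives the highest number of the three measured so far in a functional assay on the whole organism for inhibition, with Mus musculus as the target, with a stated time of 6 h, at a dose of 50 mg/kg by the oral route; on this read-out higher numbers stand for more inhibition at the one dose given (going by the name of the read-out) and lower numbers for less inhibition: in that assay compound 3 gives 54.3%. Compound 2 `Cc1ccc(-c2c(S(=O)(=O)c3ccccc3)cnc3cc(-c4ccccc4)nn23)cc1` gives 15.5%, and compound 1 `Cc1ccc(-c2c(S(=O)(=O)c3ccccc3)cnc3cc(C)nn23)cc1` gives 8.7%. The steps of a number 38.8 percentage points higher from compound 2 to compound 3 (beyond the scatter) and a number 45.6 percentage points higher from compound 1 to compound 3 (beyond the scatter) both lie beyond the scatter, whereas a number 6.8 percentage points higher from compound 1 to compound 2 (within the scatter) does not, so compound 3 stands clearly above the other two.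

Compound 4 `Cc1ccc(-c2cc3ncc(S(=O)(=O)c4ccccc4)c(-c4ccc(C)cc4)n3n2)cc1` differs from compound 3 in one place: methyl in place of bromo on an aromatic carbon. Within the data shown here, no measured step swaps bromo for methyl directly. The nearest guide is a number 38.8 percentage points higher from compound 2 to compound 3 (beyond the scatter), where the arrival of bromo went with a large rise in the read-out. Methyl, like bromo, counts as one heavy atom, but nothing measured shows whether it carries a similar rise, so the expected outcome lies between the values of compound 2 and compound 3, leaning toward a fall from compound 3 because the large gain of a number 38.8 percentage points higher from compound 2 to compound 3 (beyond the scatter) rested on bromo alone.

Compound 4 is therefore estimated to give 30% in this assay, within a range of 10% to 55%. That estimate means an expected step of a number 24.3 percentage points lower from compound 3 to compound 4 (beyond the scatter).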

Compound 4, a percentage reported as inhibition, in the whole organism at one dose (the size of the read-out at that dose, not a potency): 11.6%
Compound 4: middle estimate off by 18.4 percentage points, on the high side; the measured number falls inside the stated range.
By their numbers in this assay, from the lowest: compounds 1, 4 and 2 (each within the scatter of the next); then compound 3.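

In this assay, the rise at this place belongs to bromo itself and not to any single heavy atom there: on the six-membered aromatic ring of carbon only, para to a large group, methyl in place of bromo gives a number 42.7 percentage points lower from compound 3 to compound 4 (beyond the scatter). Methyl does not carry over what bromo brought, since methyl in place of hydrogen gives a number 3.9 percentage points lower from compound 2 to compound 4 (within the scatter) and 4-methylphenyl in place of methyl on the shared core gives a number 2.9 percentage points higher from compound 1 to compound 4 (within the scatter), which leaves compound 3 alone above the other three, with compounds 1, 2 and 4 within the scatter of one another in the ordering of their numbers. Nothing at hand explains why two groups with the same count of heavy atoms part so widely here.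

With only hydrogen, methyl and bromo shown at this place, it remains open whether chloro, fluoro, methoxy or an amine would side with bromo or with methyl in this assay. From the compounds shown here alone, the high reading also rests on compound 3 alone, at a single dose and a single time, so whether it holds across doses stays open as well.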